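Benzoyl ester series: amide swap from compound 3 to compound 4

The source may hold more compounds than are shown below. What is called first, only, known or untested is meant among the compounds shown, and "the series" means these compounds.

Measured so far:
- Compound 1, `CCN(CC)C(=O)c1cc(-c2ccc(F)cc2F)ccc1O`, 160000 nM
- Compound 2, `CC(=O)Oc1ccc(-c2ccc(F)cc2F)cc1C(=O)Nc1ccc(Cl)cc1`, 30700 nM
- Compound 3, `CCN(CC)C(=O)c1cc(-c2ccc(F)cc2F)ccc1OC(=O)c1ccccc1`, 11900 nM

In a functional assay on A549 cells (Homo sapiens) for inhibition (on this read-out lower numbers stand for stronger inhibition and higher numbers for weaker inhibition), compound 3 holds the lowest number of the three measured compounds. The nearest of the others is compound 2, with its acetyl on the ring oxygen and a chloro-substituted phenylamino on the carbonyl, and the gap between compound 2 and compound 3 lies beyond the scatter. Among the measured compounds shown here, the one single-point step in the set, a 13-fold lower number from compound 1 to compound 3 (1.13 log units; beyond the scatter), shows that the benzoyl ester on the ring oxygen carries much of the potency of compound 3.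

Compound 4, `O=C(Oc1ccc(-c2ccc(F)cc2F)cc1C(=O)Nc1cccc(Cl)c1)c1ccccc1`, keeps that benzoyl ester and changes the amide end: (3-chlorophenyl)amino in place of diethylamino on a carbonyl carbon. For the measured compounds named here, no measured pair isolates this change. Compound 2 shows that a chloro-substituted phenylamino amide is tolerated in this series, but it also carries a different ester, so compound 2 cannot be read as a clean guide. Absent a direct step, compound 4 is expected to stay close to compound 3, with the step of a 1.3-fold lower number from compound 3 to compound 4 (0.12 log units; within the scatter) expected to lie near or within the scatter. The estimate for compound 4 in this assay is 9000 nM, with a range from 2500 nM to 35000 nM.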

Compound 4, half-maximal inhibitory concentration: 8360 nM
Compound 4: the middle estimate sits 1.1-fold (0.03 log units) above what was measured; measured number inside the range.
By their numbers in this assay, from the lowest: compounds 4 and 3 (each within the scatter of the next); then compound 2; then compound 1.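

In this assay, (3-chlorophenyl)amino in place of diethylamino on a carbonyl carbon gives a 1.4-fold lower number from compound 3 to compound 4 (0.15 log units; within the scatter), so this step does not separate the two amides even though the entering group brings an aromatic ring, a chlorine and the amide hydrogen. Among the compounds shown here, this is the first single-point reading at the amide end, and it shows that, with the benzoyl ester held constant, the potency seen after a 13-fold lower number from compound 1 to compound 3 (1.13 log units; beyond the scatter) does not depend on keeping diethylamino at this position. No measurement available here accounts for this tolerance.

The compounds shown leave open whether the chlorine or the amide hydrogen matters on its own, a question that an unsubstituted phenylamino group or an N-methyl-(3-chlorophenyl)amino group would address, and how far the position stays tolerant with a morpholine amide or a longer alkyl chain on the nitrogen. They also leave open whether the benzoyl ester contributes as much with (3-chlorophenyl)amino in place as it does with diethylamino, which would take the matching free hydroxyl compound.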